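The source may hold more compounds than are shown below. What is called first, only, known or untested is meant among the compounds shown, and "the series" means these compounds.

In a functional assay for inhibition, with Rattus norvegicus as the target (a higher number here means that more compound is needed for the effect, a lower number that less compound is needed), compound 1 `CSCC[C@H](NC(=O)c1ccc(CN[C@H](CO)CC2CCCCC2)cc1-c1ccccc1C)C(=O)O` gives 190 nM and compound 3 `CCCC[C@H](CC1CCCCC1)NCc1ccc(C(=O)N[C@@H](CCSC)C(=O)O)c(-c2ccccc2C)c1` gives 4.3 nM. Compound 2 `CSCC[C@H](NC(=O)c1ccc(CN[C@H](C)CC2CCCCC2)cc1-c1ccccc1C)C(=O)O` reads > 1000 nM, which is a limit and not a number; it stands at the limit of > 1000 nM in this assay, at which 1 of the 3 values shown sits. Compound 4 `CSCC[C@H](NC(=O)c1ccc(CN(CCC2CCCCC2)C(C)=O)cc1-c1ccccc1C)C(=O)O` departs from compound 2 in one place: acetyl(2-cyclohexylethyl)amino in place of (1-(cyclohexylmethyl)ethyl)amino on a saturated chain carbon bound to an aromatic carbon.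

The measured steps that touch compound 2 both fall on a saturated chain carbon, two bonds along the chain from an amine nitrogen: an at least 5.2-fold higher number from compound 1 to compound 2 (0.72 log units; beyond the scatter) and an at least 230-fold lower number from compound 2 to compound 3 (2.36 log units; beyond the scatter). Both are beyond the scatter, so this side chain can move the number a long way. Neither step places an acetyl on the nitrogen or removes the branch, so they bear on compound 4 only loosely and give no direction for it. The estimate in this assay is a step that the limit leaves unreadable from compound 2 to compound 4, and no step beyond the scatter is expected. Compound 4 is expected at 1500 nM, with an estimated range of 250 nM to 8000 nM.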

Compound 4, half-maximal effective concentration: > 1000 nM
Compound 4: a limit, no number; the forecaster's own chance of this, stated with the estimate: 60%; the middle value is on the limit's open side.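

In this assay compound 4 reads > 1000 nM, which is a limit and not a number. Placing acetyl(2-cyclohexylethyl)amino on the saturated chain carbon bound to an aromatic carbon, in place of the hydroxy-bearing group of compound 1, gives an at least 5.2-fold higher number from compound 1 to compound 4 (0.72 log units; beyond the scatter), so this change, which alters the nitrogen and the chain together, also gives a weaker result than the hydroxy-bearing group. The step between compound 2 and compound 4 cannot be read because both compounds sit at a limit: the limit of > 1000 nM in this assay, at which 2 of the 4 values shown sit.

Since acetyl and the unbranched chain enter together, the compounds shown do not separate their contributions, and a plain secondary amine carrying the 2-cyclohexylethyl chain would address that. Also open, as far as these compounds go, is whether acetyl on the nitrogen is compatible with a butyl-type branch like that of compound 3.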